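The source may report more compounds than this note shows. Statements on the series, on what has been measured and on what is new or still open speak of the compounds shown alone.

In a functional assay on Hep cells (Homo sapiens) for cytotoxicity, read by sulforhodamine B assay, with a stated time of 48 h (a lower number here means a stronger inhibitor, a higher number a weaker inhibitor), compound 3 `O=C(c1cccnc1)c1cc(Br)ccc1O` gives 29000 nM. Within the data shown here, that is the highest of the three numbers measured so far. Its nearest neighbour is compound 1 `O=C(c1cccnc1)c1cc(Cl)ccc1O` at 27000 nM, a step of a 1.1-fold higher number from compound 1 to compound 3 (0.03 log units; within the scatter). The furthest is compound 2 `O=C(c1cccnc1)c1cc(F)ccc1O` at 12000 nM, a step of a 2.4-fold higher number from compound 2 to compound 3 (0.38 log units; beyond the scatter). The remaining measured step, a 2.3-fold lower number from compound 1 to compound 2 (0.35 log units; beyond the scatter), points the same way as that last one, so the fluoro compound stands apart while the chloro and bromo compounds sit together.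

The next compound, compound 4 `Cc1ccc(O)c(C(=O)c2cccnc2)c1`, changes one place on the shared core: methyl in place of bromo on an aromatic carbon. Among the measured compounds shown here, no measured step involves a methyl group, so the three halogen steps are the only guide, and all three keep the numbers in a narrow band, with two modest steps and one within the scatter. On that basis no step beyond the scatter is expected here. The estimated step is a 1.2-fold lower number from compound 3 to compound 4 (0.06 log units; within the scatter). Compound 4 is therefore expected to give about 25000 nM, in a range from 9000 nM to 60000 nM.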

Compound 4, half-maximal inhibitory concentration: 11000 nM
Beside the measured number, compound 4's estimate is 2.3-fold (0.36 log units) above it, within the range that was stated.
By their numbers in this assay, from the lowest: compounds 4 and 2 (each within the scatter of the next); then compounds 1 and 3 (each within the scatter of the next).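

In this assay, replacing bromo with methyl gives a 2.6-fold lower number from compound 3 to compound 4 (0.42 log units; beyond the scatter) and replacing chloro with methyl gives a 2.5-fold lower number from compound 1 to compound 4 (0.39 log units; beyond the scatter) while replacing fluoro with methyl gives a 1.1-fold lower number from compound 2 to compound 4 (0.04 log units; within the scatter) at this position, para to the hydroxy group. Methyl is the first group here that is not a halogen, and it groups with fluoro rather than with chloro and bromo, so the four compounds form two pairs, compounds 2 and 4 on one side and compounds 1 and 3 on the other. No other measurement accompanies these numbers to explain that division.

On these data alone, what a longer chain, a methoxy group or an amine would give at this position remains open. So does whether any further group would fall into one of these two pairs or outside them.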